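Hydroxy to Amino on Two Stilbene-Type Scaffolds

A few compounds are considered here, and "the series" means these few. Any claim that something is new, unique, unknown or untested is made for them only; others in the source may bear on it.

Of the compounds shown here, three have been measured so far in a functional assay on MCF7 cells (Homo sapiens) for inhibition, read by MTT assay, with a stated time of 2 days; a lower number here means a stronger inhibitor, a higher number a weaker inhibitor. Compound 1 `Oc1cccc(/C=C/c2ccccc2O)c1` gives 20.1 ug/mL. Compound 2 `Nc1cccc(/C=C/c2ccccc2O)c1`, which carries amino in place of hydroxy on an aromatic carbon, gives 24.7 ug/mL. The step from the first to the second is a 1.2-fold higher number from compound 1 to compound 2 (0.09 log units; within the scatter). Compound 3 `COc1ccccc1/C=C/c1ccc(O)cc1` gives 19 ug/mL in this assay. Among the compounds with values here, the difference between the core of compound 1 and the core of compound 3 is not broken down here; the two values, however, lie within the scatter of each other, as do all three numbers measured so far.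

Compound 4 `COc1ccccc1/C=C/c1ccc(N)cc1` has not yet been measured. It differs from compound 3 by amino in place of hydroxy on an aromatic carbon. Within the data shown here, this is the same kind of change as the one from compound 1 to compound 2, but not the same: in the earlier pair the change sits meta to a group of 9 heavy atoms, whereas here it sits para to a large group.

The expectation for compound 4 rests on a single precedent. Because the earlier change produced a 1.2-fold higher number from compound 1 to compound 2 (0.09 log units; within the scatter), the corresponding step is expected to be a 1.2-fold higher number from compound 3 to compound 4 (0.06 log units; within the scatter), which would keep compound 4 within the scatter of compound 3. On that basis compound 4 is estimated to give 22 ug/mL in this assay, with a range from 12 ug/mL to 42 ug/mL to allow for the different surroundings of the change.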

Compound 4, half-maximal inhibitory concentration: 3.2 ug/mL
The estimate for compound 4 lay 6.9-fold (0.84 log units) above the measured number; measured number below the stated range.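

In this assay, amino in place of hydroxy on an aromatic carbon, para to a large group, gives a 5.9-fold lower number from compound 3 to compound 4 (0.77 log units; beyond the scatter), a step beyond the scatter, whereas the same exchange on the core of compound 1 left the number within the scatter. The change therefore does not carry over from one core to the other with the same size in this series, and the earlier pair proved a poor guide to the later one: the same change on two cores in this assay, a 1.2-fold higher number (0.09 log units; within the scatter) from compound 1 to compound 2 and a 5.9-fold lower number (0.77 log units; beyond the scatter) from compound 3 to compound 4, 7.3-fold (0.86 log units) apart, beyond the scatter of two such steps What this does not show is the origin of the gap, since the two pairs differ both in where the exchange sits and in the rest of the core, and two pairs cannot separate these, nor do they give a rule for any further core in the series.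

The compounds shown leave open whether the lower number of compound 4 belongs to the amino group itself or would also appear with a methylamino group, an acetamide or a carboxylic acid in its place. They also leave open whether a core that keeps the methoxy group but moves the amino group would behave like compound 2 or like compound 4.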